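A Second Chloro on the Benzyl Group of Compound 1

The source may report more compounds than this note shows. Statements on the series, on what has been measured and on what is new or still open speak of the compounds shown alone.

compound 1 `Nc1nc(O)c2c(n1)n(C1OC(CO)[C@@H](O)[C@H]1O)c(=O)n2Cc1ccc(Cl)cc1` — 27%
compound 2 `C=CCn1c(=O)n(C2OC(CO[Si](C)(C)C(C)(C)C)[C@@H](O)[C@H]2O)c2nc(N)nc(O)c21` — 6%
compound 3 `C=CCn1c(=S)n(COCCO)c2nc(N)nc(O)c21` — 28%

In a functional assay on YAC-1 cells (Mus musculus) (a higher number here means a larger maximal response, a lower number a smaller maximal response), compound 1 gives 27%, the second highest of the three numbers. Compound 3 gives 28%, a number within the scatter of that of compound 1. Compound 2 gives 6%, a number beyond the scatter below compound 1.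

Compound 4 `Nc1nc(O)c2c(n1)n(C1OC(CO)[C@@H](O)[C@H]1O)c(=O)n2Cc1ccc(Cl)c(Cl)c1` differs from compound 1 by chloro in place of hydrogen on an aromatic carbon. Among the measured compounds shown here, no pair of measured compounds shows this kind of change, so there is nothing to set a size from. The expected step of a number 3 percentage points higher from compound 1 to compound 4 (within the scatter) is therefore small, in no firm direction, and not beyond the scatter. For compound 4 the estimated maximal response in this assay is 30%, expected to lie between 15% and 48%.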

Compound 4, largest response reached (reported as maximal response), in percent of the reference or control that the assay uses: 15%
Compound 4: middle estimate off by 15 percentage points, on the high side; the range from low to high includes it.
By their numbers in this assay, from the lowest: compounds 2 and 4 (each within the scatter of the next); then compounds 1 and 3 (each within the scatter of the next).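

In this assay, among the compounds shown here, the change from 4-chlorobenzyl to 3,4-dichlorobenzyl gives a number 12 percentage points lower from compound 1 to compound 4 (beyond the scatter) and so provides the first measured step in this set. It shows that this aromatic carbon, ortho to a chloro group, does not tolerate every substitution without a change in maximal response. Nothing available accounts for the drop.

From the compounds shown here alone, whether a fluoro, methyl or methoxy group on the same carbon would lower the response as well remains open. So does whether a single chloro at this carbon, without the 4-chloro group, would do the same.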